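The source may hold more compounds than are shown below. What is called first, only, known or untested is meant among the compounds shown, and "the series" means these compounds.

Working notes on the series. For the measured compounds named here, in a functional assay on HOP-62 cells (Homo sapiens) for inhibition, read by sulforhodamine B assay, with a stated time of 48 h (a higher number here means a weaker inhibitor of growth, a lower number a stronger inhibitor of growth), compound 1 `COc1ccc(-c2[nH]c3ccccc3c2/C=C(\C#N)S(=O)(=O)c2ccccc2)cc1` gives 1000 nM, and compound 2 `COc1ccc(-c2[nH]c3ccc(OC)cc3c2/C=C(\C#N)S(=O)(=O)c2ccccc2)cc1` gives 3100 nM; the one step available, a 3.1-fold higher number from compound 1 to compound 2 (0.49 log units; beyond the scatter), puts a methoxy onto the shared core. Going by the values given here, on the two numbers so far compound 2 stands highest, with compound 1 the nearest, at a gap beyond the scatter.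

Compound 3 `COc1ccc2[nH]c(-c3ccccc3)c(/C=C(\C#N)S(=O)(=O)c3ccccc3)c2c1` differs from compound 2 by hydrogen in place of methoxy on an aromatic carbon; seen one bond further out, the 4-methoxyphenyl becomes a phenyl, the methoxy having sat para to a large group. Among the compounds with values here, no measured step touches this ring: a 3.1-fold higher number from compound 1 to compound 2 (0.49 log units; beyond the scatter) concerns a methoxy on the shared core, not on the pendant phenyl, so it shows only that a methoxy at one place moved this assay modestly, and says nothing certain about the other. Within the data shown here, with no direct precedent, the expectation for compound 3 in this assay is a number near that of compound 2, with a change in either direction of modest size, estimated as a 1.2-fold lower number from compound 2 to compound 3 (0.09 log units; within the scatter). The estimate for compound 3 is 2500 nM, within 900 nM to 7000 nM.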

Compound 3, concentration for 50% growth inhibition: 8300 nM
The estimate for compound 3 lay 3.3-fold (0.52 log units) below the measured number; the measured number lies above the stated range.
By their numbers in this assay, from the lowest: compound 1; then compound 2; then compound 3.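

In this assay, the change from 4-methoxyphenyl to phenyl gives a 2.7-fold higher number from compound 2 to compound 3 (0.43 log units; beyond the scatter), so with the core methoxy present, the methoxy para to a large group goes with stronger growth inhibition and its removal weakens it. This runs in the opposite direction to a 3.1-fold higher number from compound 1 to compound 2 (0.49 log units; beyond the scatter), where a methoxy entering on the shared core weakens growth inhibition; across these compounds, the direction of the methoxy step therefore depends on where the group sits. For the compounds shown here, both steps are beyond the scatter, but the reading at the phenyl is tied to the single pair that carries the core methoxy, and nothing measured here bears on why the number moves.

Going by these compounds, whether the step from 4-methoxyphenyl to phenyl keeps its direction and size without the core methoxy remains open. Also open, on these data alone, is whether the methoxy is specifically required at this place, or whether a hydroxy, an ethoxy, a dimethylamino group or a fluorine there would give a similar number in this assay.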